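Swapping an Aminomethyl for a Methoxycarbonyl Group

The source may report more compounds than this note shows. Statements on the series, on what has been measured and on what is new or still open speak of the compounds shown alone.

Within the data shown here, the three compounds measured so far share one core and differ only in a small group on one ring. Compound 1 `CC(C)CCn1c(Cn2c(=O)n(C(C)C)c3ccccc32)nc2cc(CN)ccc21`, which carries an aminomethyl group, gives 3920 nM in an ADME assay on HEp-2 cells (Homo sapiens) for cytotoxicity; a lower number here means that less compound is tolerated, a higher number that more compound is tolerated. This is the lowest of the three numbers, so compound 1 is tolerated at the lowest concentration seen here. Compound 2 `CNCc1ccc2nc(Cn3c(=O)n(C(C)C)c4ccccc43)n(CCC(C)C)c2c1`, with a methylaminomethyl group, gives 4810 nM in this assay, a number that lies within the scatter of compound 1. Compound 3 `CC(C)CCn1c(Cn2c(=O)n(C(C)C)c3ccccc32)nc2c(CO)cccc21`, with a hydroxymethyl group, gives 22000 nM in this assay, which is beyond the scatter and means more of compound 3 is tolerated than of compound 1.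

Compound 4 `COC(=O)c1ccc2c(c1)nc(Cn1c(=O)n(C(C)C)c3ccccc31)n2CCC(C)C` has not been measured. It differs from compound 1 in one place: methoxycarbonyl in place of aminomethyl on an aromatic carbon. Among the measured compounds shown here, no pair of measured compounds shows this particular exchange, so the size of the step cannot be read from the data. Because compound 3, which also lacks the aminomethyl group, gives 22000 nM, a modest move toward more tolerated compound is expected, though it may not exceed the scatter. The expected step is a 1.8-fold higher number from compound 1 to compound 4 (0.25 log units; within the scatter), and compound 4 is estimated at 7000 nM, with a range from 3000 nM to 20000 nM.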

Compound 4, half-maximal cytotoxic concentration: 33700 nM
The estimate for compound 4 lay 4.8-fold (0.68 log units) below the measured number, and the stated range ends below it.
By their numbers in this assay, from the lowest: compounds 1 and 2 (each within the scatter of the next); then compounds 3 and 4 (each within the scatter of the next).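

In this assay, among these compounds, methoxycarbonyl in place of aminomethyl on this aromatic carbon gives an 8.6-fold higher number from compound 1 to compound 4 (0.93 log units; beyond the scatter), the first step in the set between two compounds that differ in only one place. It shows that the group on this ring carbon can by itself shift the tolerated concentration by more than the usual scatter of repeated measurements, with the rest of the molecule unchanged. The exchange replaces 2 heavy atoms with 4 and 1 hydrogen-bond donor with 0, but this single step cannot show which of these differences, if any, matters, and no measurement shown here accounts for its size.

The compounds shown leave open whether the step comes from removing aminomethyl or from adding methoxycarbonyl, a question that a plain hydrogen or a methyl group on the same carbon could help to separate. They also leave open how closely related groups on this carbon would compare, such as a carboxylic acid, a primary amide or an ethyl ester, and whether the same exchange would give a similar step on a different ring carbon.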